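Nitropyrimidine esters: methoxy removal on the aryl ring

The compounds below may be only part of what the source reports. "The series", "measured", "known", "first", "only" and "open" are said of these compounds alone.

Measured compounds:
compound 1, `CCOC(=O)CN(Cc1ccccc1)c1nc(NCc2ccccc2)ncc1[N+](=O)[O-]`, 82400 nM
compound 2, `CCOC(=O)CN(Cc1ccccc1)c1nc(NCc2cccc(OC)c2)ncc1[N+](=O)[O-]`, 80700 nM
compound 3, `COC(=O)CN(C)c1nc(Nc2cccc(OC)c2)ncc1[N+](=O)[O-]`, 58000 nM

All three were run in a functional assay on MDA-MB-231 cells (Homo sapiens) for antiproliferative activity, read by MTT assay, with a stated time of 48 h; a higher number here means a weaker inhibitor, a lower number a stronger inhibitor. Compound 1 gives 82400 nM, compound 2 gives 80700 nM and compound 3 gives 58000 nM; the three values sit within the scatter of one another, so no order among them is claimed.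

Compound 2 and compound 1 differ by one change, (hydrogen in place of methoxy on an aromatic carbon), and the step of a 1.0-fold higher number from compound 2 to compound 1 (0.01 log units; within the scatter) is flat. The difference between the core of compound 3 and the core of compound 2 is not broken down here.

Compound 4, `COC(=O)CN(C)c1nc(Nc2ccccc2)ncc1[N+](=O)[O-]`, has not yet been measured. It relates to compound 3 by hydrogen in place of methoxy on an aromatic carbon, the same kind of change as from compound 2 to compound 1, at a place described in the same terms. Because the earlier step of a 1.0-fold higher number from compound 2 to compound 1 (0.01 log units; within the scatter) was flat, the step from compound 3 to compound 4 in this assay is expected to be flat as well, a 1.0-fold higher number from compound 3 to compound 4 (0.01 log units; within the scatter). Compound 4 is therefore estimated at 60000 nM, with a range of 30000 nM to 120000 nM.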

Compound 4, half-maximal inhibitory concentration: > 100000 nM
Compound 4: only a limit was reported; the forecaster's own chance of this, stated with the estimate: 10%; middle value at least 1.6-fold (0.22 log units) away from the limit.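

Compound 4 gives > 100000 nM in this assay, which is a limit and not a number: the limit of > 100000 nM in this assay, at which 1 of the 4 values shown sits.

Going from 3-methoxyphenyl to phenyl on the core of compound 3 gives an at least 1.7-fold higher number from compound 3 to compound 4 (0.23 log units; that floor lies within the scatter), so only a floor is known for this step, and that floor does not separate the two compounds. Set beside the same change on the core of compound 2, the result neither shows that the flat outcome carries over to the core of compound 3 nor shows that the change behaves differently there: the same change on two cores in this assay, a 1.0-fold higher number (0.01 log units; within the scatter) from compound 2 to compound 1 and an at least 1.7-fold higher number (0.23 log units; that floor lies within the scatter) from compound 3 to compound 4; the limit leaves it open whether they differ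

On these data alone, the true size of the step on the core of compound 3 remains open, as does whether any other group on the aromatic ring would behave as hydrogen or methoxy does here. Also open, as far as these compounds go, is how this change would read with a carboxylic acid in place of the ester, or with an amine or a longer chain on the aromatic ring.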